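Swapping the aryl group where both parents sit at the limit

The compounds below may be only part of what the source reports. "The series", "measured", "known", "first", "only" and "open" are said of these compounds alone.

Measured so far:
- compound 1 `OC[C@H]1O[C@@H](n2cnc3c(NCc4ccc(Cl)cc4)ncnc32)[C@H](O)[C@@H]1O`: in a functional assay on G-361 cells (Homo sapiens) for antiproliferative activity, with a stated time of 72 h (on this read-out higher numbers stand for weaker inhibition and lower numbers for stronger inhibition), compound 1 gives > 166000 nM, which is a limit of the assay and not a number.
- compound 2 `OC[C@H]1O[C@@H](n2cnc3c(NCc4c(F)ccc(F)c4F)ncnc32)[C@H](O)[C@@H]1O`: in this assay compound 2 gives > 166000 nM, again a limit of the assay rather than a number.

Compound 1 therefore stands only at a limit in this assay, and no number is known for it. Within the data shown here, the single step among the measured compounds, a step that the two limits leave unreadable from compound 1 to compound 2, is unreadable for the same reason, since (the limit of > 166000 nM in this assay, at which 2 of the 2 values shown sit).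

The unmeasured compound 3 `OC[C@H]1O[C@@H](n2cnc3c(NCc4cccc(C(F)(F)F)c4)ncnc32)[C@H](O)[C@@H]1O` differs from compound 1 by 3-(trifluoromethyl)phenyl in place of 4-chlorophenyl on a saturated chain carbon bound to a nitrogen on an aromatic ring. Among the measured compounds shown here, the only measured step that bears on this change is the one from compound 1 to compound 2, which also replaces the aryl group at the same place; its size cannot be read. No readable step exists in this assay from which a direction could be taken.

With both parents at the limit, compound 3 is expected to sit there too, an estimated 166000 nM with a range from 50000 nM to 500000 nM, a step of a number no higher from compound 1 to compound 3 (the limit leaves the size open) that is expected to be unreadable in practice.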

Compound 3, half-maximal inhibitory concentration: > 166000 nM
Compound 3: a limit, no number; the forecaster's own chance of this, stated with the estimate: 85%; the middle value sits exactly at the limit.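

In this assay compound 3 gives > 166000 nM, a limit and not a number. The steps to compound 3 from compound 1 and from compound 2 therefore cannot be read: the limit of > 166000 nM in this assay, at which 3 of the 3 values shown sit.

The compounds shown leave open whether any aryl group at this place on the shared core gives a readable value, and how far compound 1, compound 2 and compound 3 differ.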